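Swapping the halogenated aryl group on the shared core

A few compounds are considered here, and "the series" means these few. Any claim that something is new, unique, unknown or untested is made for them only; others in the source may bear on it.

Measured compounds:
compound 1, `CC(C)c1ccc(Nc2ccc3c(OCCCN4CCN(C)CC4)cccc3n2)cc1`, 18800 nM
compound 2, `CN1CCN(CCCOc2cccc3nc(Nc4ccc(F)c(F)c4)ccc23)CC1`, 5510 nM

The two compounds above share one core and differ only in the aryl group attached to the nitrogen on the aromatic ring. In a functional assay on NCI-H226 cells (Homo sapiens) for inhibition, read by sulforhodamine B assay, with a stated time of 48 h (on this read-out lower numbers stand for stronger inhibition of growth and higher numbers for weaker inhibition of growth), compound 2 gives the lower of the two numbers, and the step of a 3.4-fold lower number from compound 1 to compound 2 (0.53 log units; beyond the scatter) shows that the 3,4-difluorophenyl group went with stronger growth inhibition than the 4-isopropylphenyl group.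

Among the compounds with values here, compound 3, `CN1CCN(CCCOc2cccc3nc(Nc4cccc(Cl)c4)ccc23)CC1`, keeps the whole core of compound 2 and changes only that aryl group: 3-chlorophenyl in place of 3,4-difluorophenyl on a nitrogen on an aromatic ring. Within the data shown here, the single measured step, a 3.4-fold lower number from compound 1 to compound 2 (0.53 log units; beyond the scatter), concerns a different exchange, from a branched alkyl-bearing phenyl to a halogenated phenyl, so it bears on the present change only loosely. Compound 3 carries a halogenated phenyl much as compound 2 does, so the expected step of a 1.1-fold lower number from compound 2 to compound 3 (0.04 log units; within the scatter) is small and may well sit within the scatter. Compound 3 is therefore estimated to give 5000 nM in this assay, with a range from 2000 nM to 15000 nM.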

Compound 3, concentration for 50% growth inhibition: 1620 nM
Beside the measured number, compound 3's estimate is 3.1-fold (0.49 log units) above it, outside the stated range (below it).
By their numbers in this assay, from the lowest: compound 3; then compound 2; then compound 1.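

In this assay, the step of a 3.4-fold lower number from compound 2 to compound 3 (0.53 log units; beyond the scatter) shows that this position separates even two halogen-bearing phenyl groups, so carrying a halogen does not by itself fix the result. 3-Chlorophenyl and 3,4-difluorophenyl differ in which halogen they carry, how many halogen atoms they have and where these sit, and on the shared core that exchange is as large as the earlier move away from 4-isopropylphenyl. The two exchanges run in the same direction, and the full span across the three aryl groups, a 12-fold lower number from compound 1 to compound 3 (1.06 log units; beyond the scatter), shows that a change at this one position can shift growth inhibition substantially, with compound 3 the strongest of the three and no available evidence explaining the difference.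

Because 3,4-difluorophenyl and 3-chlorophenyl differ in more than one respect, the compounds shown leave open whether the gain follows the chlorine atom itself or the simpler substitution pattern. Comparing 3-fluorophenyl, 4-chlorophenyl and 3,4-dichlorophenyl on the same core would help separate these possibilities, and unsubstituted phenyl would show what the halogens contribute at all.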